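Bromine in Place of a Small Group on the Shared Core

This account rests on a few compounds, and the source may have more. Where it says the series, first, only, none or still open, it means among the compounds named here.

Compound 1 `CC1(C)C(=O)N(c2ccc(S(C)(=O)=O)cc2)c2ncccc21` and compound 2 `C[S+]([O-])c1ccc(N2C(=O)C(C)(C)c3cccnc32)cc1` share one core and differ at a single aromatic carbon. In a functional assay on the whole organism (Pleural cavity) for inhibition, with Rattus norvegicus as the target, at a dose of 25 mg/kg (on this read-out lower numbers stand for less inhibition and higher numbers for more inhibition at the one dose given (going by the name of the read-out)), compound 1 gives 42%, while compound 2 gives 39%. The step of a number 3 percentage points lower from compound 1 to compound 2 (within the scatter) lies within the scatter. Compound 2 thus stands lowest of the two numbers, yet its nearest neighbour, compound 1, sits within the scatter of it, so the pair shows no real difference.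

Compound 3 `CC1(C)C(=O)N(c2ccc(Br)cc2)c2ncccc21` has not yet been measured. Its change from compound 2 is one bromine atom in place of a group of 3 heavy atoms (1 carbon, 1 oxygen, 1 sulfur; no ring), on an aromatic carbon. Among the measured compounds shown here, the only measured step touches the same aromatic carbon, but there the group that enters and the group that leaves are close in make-up, and the read-out stays flat. Bromine is a different kind of replacement, and no measured step speaks to it directly, so the expectation rests on the flatness seen so far.

Compound 3 is therefore estimated to give 38% in this assay, within a range from 15% to 60%. The expected step of a number 1 percentage points lower from compound 2 to compound 3 (within the scatter) is thus no change beyond the scatter.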

Compound 3, a percentage reported as inhibition, in the whole organism at one dose (the size of the read-out at that dose, not a potency): 46%
For compound 3 the middle estimate is 8 percentage points below the measured one; measured number inside the range.
By their numbers in this assay, from the lowest: compounds 2, 1 and 3 (each within the scatter of the next).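

In this assay, the exchange of the sulfur-bearing group for one bromine atom gives a number 7 percentage points higher from compound 2 to compound 3 (within the scatter), and bromo in place of methylsulfonyl gives a number 4 percentage points higher from compound 1 to compound 3 (within the scatter), both on the same aromatic carbon, para to a large group. Among the compounds shown here, the earlier pair compared only two groups that each hold sulfur and oxygen, whereas this result shows that a single bromine atom, with no hydrogen-bond acceptor and neither of those elements, also leaves the three compounds within the scatter of one another, so among them a sulfur-bearing group at this place is not needed for a number of this size. No measurement at hand bears on why the read-out stays level across so different a change.

The compounds shown leave open whether any group at this aromatic carbon moves the number beyond the scatter, since bromo and the two sulfur-bearing groups cannot be told apart. An amine, a carboxylic acid or a longer alkyl chain in this place could test that, and plain hydrogen there would show whether the position needs a substituent at all.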